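This account rests on a few compounds, and the source may have more. Where it says the series, first, only, none or still open, it means among the compounds named here.

In this study a small set of compounds built on closely related cores is tested for cytotoxicity in a functional assay on BXPC-3 cells (Homo sapiens) for cytotoxicity, read by MTT assay, with a stated time of 72 h, tested at 1 uM; on this read-out higher numbers stand for a weaker effect at the one concentration tested and lower numbers for a stronger effect. Compound 1, `C=C1C(=O)O[C@@H](c2ccccc2)[C@H]1C`, gives 98% in this assay. Compound 2, `C=C1C(=O)O[C@@H](c2ccc(OC)cc2)[C@H]1C`, differs from compound 1 in a single place: methoxy in place of hydrogen on an aromatic carbon. In this assay compound 2 gives 128%, and the step is a number 30 percentage points higher from compound 1 to compound 2 (beyond the scatter).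

Compound 3, `C=C1C(=O)O[C@H](c2ccccc2)[C@H]1c1ccccc1`, rests on a different core, and the difference between the two cores is not broken down here. In this assay compound 3 gives 86%, the lowest of the three numbers and beyond the scatter from both compound 1 and compound 2.

Compound 4, `C=C1C(=O)O[C@H](c2ccc(OC)cc2)[C@H]1c1ccccc1`, has not yet been measured. It differs from compound 3 by methoxy in place of hydrogen on an aromatic carbon. This is the same kind of change as that from compound 1 to compound 2, though not the same change: in compound 2 the methoxy stands para to a group of 8 heavy atoms, whereas in compound 4 it stands para to a large group. Resting on the earlier result of a number 30 percentage points higher from compound 1 to compound 2 (beyond the scatter), the expected step is a number 19 percentage points higher from compound 3 to compound 4 (beyond the scatter), a move in the same direction and on a similar or somewhat smaller scale. Compound 4 is therefore estimated at 105%, with a likely range from 85% to 130%.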

Compound 4, a percentage reported as activity, at one concentration (the size of the read-out at that concentration, not a potency): 73%
Compound 4: the middle estimate sits 32 percentage points above what was measured; the measured number lies below the stated range.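

On the core of compound 3, methoxy in place of hydrogen on an aromatic carbon gives a number 13 percentage points lower from compound 3 to compound 4 (beyond the scatter) in this assay. Set beside the earlier step, this shows that the change does not carry over from the core of compound 1 to the core of compound 3 with its direction kept, and the two steps differ by more than scatter would allow: the same change on two cores in this assay, a number 30 percentage points higher (beyond the scatter) from compound 1 to compound 2 and a number 13 percentage points lower (beyond the scatter) from compound 3 to compound 4, 43 percentage points apart, beyond the scatter of two such steps

The comparison rests on a single pair on each core, read at one concentration in one cell line, so it shows only that the outcome of this change depends on the core in these four compounds; it does not show which feature of the two cores decides the direction, nor how the change would behave on any further core.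

The compounds shown leave open whether another group in the same place, such as a hydroxyl, a fluorine or an amine, would follow the methoxy on either core. They also leave open whether the opposite directions of the two steps would persist across a range of concentrations rather than at the single one tested.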